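Ethoxy to Ethylamino on a Shared Diaryl Amine Core

The source may hold more compounds than are shown below. What is called first, only, known or untested is meant among the compounds shown, and "the series" means these compounds.

Measured compounds:
compound 1, `CCOc1cccnc1Nc1cccc(C)n1`: 40 nM
compound 2, `CCOc1cccnc1Nc1cccc(C(F)(F)F)n1`: 1900 nM

Among the compounds with values here, compound 1 in an assay on Ltk cells with metabotropic glutamate receptor 5 (Homo sapiens) as the target, read by fluorescence and calcium flux (a lower number here means a stronger inhibitor, a higher number a weaker inhibitor), stands at the lower of the two numbers recorded; its only neighbour is compound 2, and the step of a 48-fold higher number from compound 1 to compound 2 (1.68 log units; beyond the scatter) is the sole measured change. That step concerns the methyl on the second ring and says nothing directly about the group that compound 3 alters.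

Compound 3, `CCNc1cccnc1Nc1cccc(C)n1`, differs from compound 1 by ethylamino in place of ethoxy on an aromatic carbon. Within the data shown here, no measured pair bears on this exchange, so the direction of the step cannot be drawn from the data; a change beyond the scatter is possible in either direction, and a modest weakening is taken as the more likely outcome. Compound 3 is therefore estimated at 120 nM, with a range from 30 nM to 500 nM. The expected step is a 3.0-fold higher number from compound 1 to compound 3 (0.48 log units; beyond the scatter).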

Compound 3, half-maximal inhibitory concentration: 3000 nM
Compound 3: the middle estimate sits 25-fold (1.40 log units) below what was measured; measured number outside the range, above it.
By their numbers in this assay, from the lowest: compound 1; then compounds 2 and 3 (each within the scatter of the next).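

In this assay, ethylamino in place of ethoxy on an aromatic carbon gives a 75-fold higher number from compound 1 to compound 3 (1.88 log units; beyond the scatter), a large loss from a swap that leaves the count of heavy atoms unchanged but brings in a hydrogen-bond donor that ethoxy lacks. Within the data shown here, the earlier pair kept ethoxy fixed and changed only the methyl, so this is the first sign that the position two atoms from the ring nitrogen is itself highly sensitive to what stands on it. Nothing measured on these groups accounts for the loss.

The compounds shown leave open whether the oxygen of ethoxy matters or the hydrogen on the ethylamino nitrogen does, which dimethylamino could help separate. They also leave open how far the chain can vary at this position, as with methoxy or propoxy.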